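Removing the phenylcarbamoyl group from compound 2

A few compounds are considered here, and "the series" means these few. Any claim that something is new, unique, unknown or untested is made for them only; others in the source may bear on it.

Measured so far in an ADME assay on MAGI cells (Homo sapiens) for cytotoxicity; on this read-out higher numbers stand for lower toxicity in this test and lower numbers for higher toxicity in this test:
- compound 1 `NCCCCN(C[C@H]1CN(C(=O)OCc2ccccc2)CCN1)[C@H]1CCCc2cccnc21`: > 10 uM
- compound 2 `NCCCCN(C[C@H]1CN(C(=O)Nc2ccccc2)CCN1)[C@H]1CCCc2cccnc21`: > 10 uM

Neither entry is a number, as both are limits. Compound 2 stands at the limit > 10 uM in this assay. The evidence so far is the limit of > 10 uM in this assay, at which 2 of the 2 values shown sit. Among the measured compounds shown here, the only measured step, a step that the two limits leave unreadable from compound 1 to compound 2, cannot be sized, so it offers no measure for the next change.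

Compound 3 `NCCCCN(C[C@H]1CNCCN1)[C@H]1CCCc2cccnc21` differs from compound 2 by hydrogen in place of phenylcarbamoyl on an amine nitrogen in a ring. For the measured compounds named here, no measured step covers this change, so no shift beyond the scatter is expected in this assay, in either direction, and another limit is a likely result. The expected step is a step that the limit leaves unreadable from compound 2 to compound 3. The estimate for compound 3 is 20 uM, with an expected range of 8 uM to 60 uM.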

Compound 3, half-maximal toxic concentration: > 10 uM
Compound 3 was reported as a limit (the forecaster's own chance of this, stated with the estimate: 70%); the middle value does not contradict the limit.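

Among the compounds shown here, compound 1, compound 2 and compound 3 are all reported as limits in this assay, so no step among them can be read. The compounds shown leave open at what concentration any of the three becomes toxic in this assay.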